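Fluorine on the benzyl arm of a pyrazole hydroxamate series

The source may hold more compounds than are shown below. What is called first, only, known or untested is meant among the compounds shown, and "the series" means these compounds.

Three compounds sharing one core were examined in a functional assay on HeLa cells (Homo sapiens) for antiproliferative activity, read by MTT assay, with a stated time of 48 h, in the presence of a further agent that is not named here; on this read-out higher numbers stand for weaker inhibition of growth and lower numbers for stronger inhibition of growth. Compound 1 `Cc1ccc(-c2nn(-c3ccccc3)cc2C(=O)NOCc2ccccc2)cc1` gives 6690 nM in this assay. Compound 2 `Cc1ccc(-c2nn(-c3ccccc3)cc2C(=O)NOCc2ccccc2F)cc1` carries a single added fluorine, the change described as fluoro in place of hydrogen on an aromatic carbon, and in this assay compound 2 gives 1180 nM. Among the measured compounds shown here, the resulting step, a 5.7-fold lower number from compound 1 to compound 2 (0.75 log units; beyond the scatter), is the only change of this type measured so far, so it rests on one pair alone.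

The second core differs from the first in the way described as chloro in place of methyl on an aromatic carbon. Compound 3 `O=C(NOCc1ccccc1)c1cn(-c2ccccc2)nc1-c1ccc(Cl)cc1` gives 8350 nM in this assay, and the step of a 1.2-fold higher number from compound 1 to compound 3 (0.10 log units; within the scatter) shows that the two cores are not distinguishable on this read-out.

Compound 4 `O=C(NOCc1ccccc1F)c1cn(-c2ccccc2)nc1-c1ccc(Cl)cc1` has not yet been measured. It differs from compound 3 in the way described as fluoro in place of hydrogen on an aromatic carbon; the place of the change is described in the same words as for compound 2, so this is the same change carried onto the other core. Because the step of a 5.7-fold lower number from compound 1 to compound 2 (0.75 log units; beyond the scatter) was made on a core that this assay could not tell apart from the core of compound 3, the step from compound 3 to compound 4 is expected to be of a similar size, a 5.2-fold lower number from compound 3 to compound 4 (0.72 log units; beyond the scatter), though with wide bounds since it rests on a single pair. Compound 4 is therefore estimated to give 1600 nM in this assay, expected to lie between 600 nM and 4500 nM.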

Compound 4, concentration for 50% growth inhibition: 4170 nM
Compound 4: the middle estimate sits 2.6-fold (0.42 log units) below what was measured; the range from low to high includes it.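

In this assay, the change from benzyl to 2-fluorobenzyl on the core of compound 3 gives a 2.0-fold lower number from compound 3 to compound 4 (0.30 log units; within the scatter), so a step that stood beyond the scatter on the core of compound 1 does not do so here, and the two steps differ: the same change on two cores in this assay, a 5.7-fold lower number (0.75 log units; beyond the scatter) from compound 1 to compound 2 and a 2.0-fold lower number (0.30 log units; within the scatter) from compound 3 to compound 4, 2.8-fold (0.45 log units) apart, beyond the scatter of two such steps. Seen from the other side, chloro in place of methyl, which could not be told apart from no change without the fluoro group, gives a 3.5-fold higher number from compound 2 to compound 4 (0.55 log units; beyond the scatter) when the fluoro group is present, and this pair of steps differs by the same amount: the same change on two cores in this assay, a 1.2-fold higher number (0.10 log units; within the scatter) from compound 1 to compound 3 and a 3.5-fold higher number (0.55 log units; beyond the scatter) from compound 2 to compound 4, 2.8-fold (0.45 log units) apart, beyond the scatter of two such steps. In these four compounds, then, the size of the fluoro step did not carry over intact from one core to the other and the two changes do not act independently on this read-out, but each step rests on a single pair, and the data show neither why the steps differ nor how the fluoro step would behave on any further core.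

The compounds shown leave open whether a core carrying bromo or methoxy in place of methyl or chloro would follow compound 2 or compound 4. They also leave open whether chloro or a nitrile in place of the fluoro group on the benzyl arm would show the same dependence on the core.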